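The source may report more compounds than this note shows. Statements on the series, on what has been measured and on what is new or still open speak of the compounds shown alone.

Two compounds share one core. Compound 1 `COc1cc(-c2cc(/C=C/C(=O)c3ccc(Cl)c(Cl)c3)[nH]n2)cc(OC)c1OC` gives 94% in a functional assay on MDA-MB-468 cells (Homo sapiens) for cytotoxicity, read by sulforhodamine B assay, with a stated time of 48 h, tested at 0.01 uM (on this read-out lower numbers stand for a stronger effect and higher numbers for a weaker effect at the one concentration tested), and compound 2 `COc1ccc(C(=O)/C=C/c2cc(-c3cc(OC)c(OC)c(OC)c3)n[nH]2)cc1` gives 89% in this assay. Of these two numbers, compound 2 holds the lower one, with compound 1 its nearest neighbour, yet the step of a number 5 percentage points lower from compound 1 to compound 2 (within the scatter) lies within the scatter, so the two cannot be told apart on this read-out. Compound 3 `COc1cc(-c2cc(/C=C/C(=O)c3ccc(F)c(F)c3)[nH]n2)cc(OC)c1OC` has not yet been measured in this assay. It differs from compound 2 by 3,4-difluorophenyl in place of 4-methoxyphenyl on a carbonyl carbon. For the measured compounds named here, the single measured step bearing on this, a number 5 percentage points lower from compound 1 to compound 2 (within the scatter), also exchanged one aryl group for another on the carbonyl carbon and stayed within the scatter. The expected step is therefore a number 1 percentage points higher from compound 2 to compound 3 (within the scatter), again within the scatter. Compound 3 is estimated at 90%, with a range from 80% to 98%.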

Compound 3, a percentage reported as activity, at one concentration (the size of the read-out at that concentration, not a potency): 90%
For compound 3 middle estimate and measured number coincide at the digits printed; low and high end bracket the measured number.
By their numbers in this assay, from the lowest: compounds 2, 3 and 1 (each within the scatter of the next).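

In this assay the exchange on the carbonyl carbon now spans three aryl groups, and replacing 4-methoxyphenyl with 3,4-difluorophenyl gives a step that cannot be read as a change (a number 1 percentage points higher from compound 2 to compound 3 (within the scatter)). Replacing 3,4-dichlorophenyl with 3,4-difluorophenyl gives the same outcome (a number 4 percentage points lower from compound 1 to compound 3 (within the scatter)), so the fluorine and chlorine pair on this aryl ring cannot be told apart on this read-out, and neither can be told apart from 4-methoxyphenyl. No available evidence accounts for these three groups reading alike. As far as these compounds go, it remains open whether a group of another kind on the carbonyl carbon, such as an aminophenyl group, a carboxylic acid or a longer chain, would move the number beyond the scatter. From the compounds shown here alone, whether compounds 1, 2 and 3 differ at other concentrations also remains open.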